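Extending the Chain on the Ring Nitrogen of Compound 3

The source may report more compounds than this note shows. Statements on the series, on what has been measured and on what is new or still open speak of the compounds shown alone.

Compound 1, `CC(C)(C)c1ccc2nc(N)sc2c1`: 4 mg/kg
Compound 2, `Nc1nc2ccc(CC(F)(F)F)cc2s1`: 8 mg/kg
Compound 3, `CCn1c(=N)sc2cc(OC(F)(F)F)ccc21`: 5 mg/kg

In a functional assay on the whole organism with Rattus norvegicus as the target (on this read-out higher numbers stand for an effect only at larger amounts of compound and lower numbers for an effect already at smaller amounts), compound 3 gives 5 mg/kg, the second highest of the three numbers, yet compound 1 and compound 2 both lie within the scatter of it. Compound 4, `CCCSCCn1c(=N)sc2cc(OC(F)(F)F)ccc21`, differs from compound 3 by propylsulfanyl in place of hydrogen on a saturated chain carbon, two bonds along the chain from an aromatic nitrogen. Among the measured compounds shown here, the one measured step, a 2.0-fold higher number from compound 1 to compound 2 (0.30 log units; within the scatter), concerns a group on an aromatic carbon and stays within the scatter; no measured step touches the saturated chain on the ring nitrogen. The expectation for compound 4 in this assay is therefore a step of no change at the digits printed from compound 3 to compound 4 (within the scatter), not beyond the scatter. Compound 4 is estimated at 5 mg/kg, with a range from 2 mg/kg to 12 mg/kg.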

Compound 4, dose for half-maximal effect: 2.4 mg/kg
The estimate for compound 4 lay 2.1-fold (0.32 log units) above the measured number; measured number inside the range.
By their numbers in this assay, from the lowest: compounds 4, 1, 3 and 2 (each within the scatter of the next, the first and the last beyond it).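

In this assay, among the compounds shown here, the saturated chain on the ring nitrogen gives the first step that passes the scatter, with propylsulfanyl in place of hydrogen on a saturated chain carbon, two bonds along the chain from an aromatic nitrogen (a 2.1-fold lower number from compound 3 to compound 4 (0.32 log units; beyond the scatter)). The position therefore accepts this longer chain, and the number moves modestly towards smaller amounts. Nothing measured here gives a reason for the shift.

The compounds shown leave open whether the sulfur or the chain itself matters. A plain pentyl chain, an ether or an amine at the same carbon would bear on this.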